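The source may hold more compounds than are shown below. What is called first, only, known or untested is meant among the compounds shown, and "the series" means these compounds.

Measured compounds in an ADME assay on BJ cells (Homo sapiens) for cytotoxicity, with a stated time of 72 h; a lower number here means that less compound is needed, a higher number that more compound is needed for the effect:

compound 1, `Cc1cc(NC(=O)Nc2ncccc2C)c2ccccc2n1` — > 25000 nM
compound 2, `Cc1cc(NC(=O)Nc2ccc(Cl)cc2)c2ccccc2n1` — > 25000 nM

In this assay compound 1 gives only a limit of the assay, > 25000 nM. Compound 2 likewise gives only a limit, > 25000 nM. Going by the values given here, the one measured step, a step that the two limits leave unreadable from compound 1 to compound 2, therefore cannot be read, since both its ends sit at a limit. Among the compounds with values here, compound 2 thus stands at a limit and not at a number, and the sole piece of evidence on the measured steps is the limit of > 25000 nM in this assay, at which 2 of the 2 values shown sit.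

Compound 3, `Cc1cc(NC(=O)Nc2ccc(Cl)cc2Cl)c2ccccc2n1`, differs from compound 2 in one place: chloro in place of hydrogen on an aromatic carbon. No measured step bears on this change, and the only step shown is itself unreadable, so no direction and no size can be drawn from it. Compound 3 is expected to show no step beyond the scatter, with a step that the limit leaves unreadable from compound 2 to compound 3, and to give again only a limit of the assay. For compound 3 the estimate in this assay is 40000 nM, between 20000 nM and 100000 nM.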

Compound 3, half-maximal effective concentration: 20000 nM
Compound 3: the middle estimate sits 2.0-fold (0.30 log units) above what was measured, and the stated range covers the measured number.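

In this assay, going by these compounds alone, compound 3 gives the only one of the three values shown that is a number and not a limit, so this position yields a step that can be read, at least in part, unlike the earlier pair. Chloro in place of hydrogen on an aromatic carbon, ortho to a large group and meta to a chloro group, gives an at least 1.2-fold lower number from compound 2 to compound 3 (0.09 log units; that floor lies within the scatter). Since only this floor is known, the change cannot be said to go beyond the scatter, and the other values stay at a limit: the limit of > 25000 nM in this assay, at which 2 of the 3 values shown sit.

On these data alone, the true size of the step remains open, as one end of it is a limit. Also open, as far as these compounds go, is whether fluoro, methoxy or an amine on the same aromatic carbon would give a number in this assay, or whether such a value is tied to chloro.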